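A methyl cap on a hydroxymethyl compound

The compounds below may be only part of what the source reports. "The series", "measured", "known", "first", "only" and "open" are said of these compounds alone.

compound 1 (`Cc1cccc(-c2nn3c(c2-c2ccncc2)C(CO)C(C)(C)C3)n1`) : > 100000 nM (a limit)
compound 2 (`Cc1cccc(-c2nn3c(c2-c2ccncc2)C(C)C(C)(C)C3)c1C#N`) : 97000 nM

In a functional assay on MCF7 cells (Homo sapiens) for cytotoxicity, with a stated time of 72 h (a lower number here means a stronger inhibitor, a higher number a weaker inhibitor), compound 1 gives > 100000 nM as a limit of the assay and not a number. Compound 1 thus stands at the limit of > 100000 nM in this assay, at which 1 of the 2 values shown sits, and has no exact value. For the measured compounds named here, compound 2 reads 97000 nM in this assay and supplies the only number. Compound 3 (`COCC1c2c(-c3ccncc3)c(-c3cccc(C)n3)nn2CC1(C)C`) differs from compound 1 by methyl in place of hydrogen on an oxygen on a saturated carbon, hydroxymethyl to methoxymethyl (methyl in place of hydrogen on an oxygen on a saturated carbon). No measured step sizes this change, so in this assay the expected step (a number no higher from compound 1 to compound 3 (the limit leaves the size open)) lies within the scatter, with no direction expected. The estimate for compound 3 is 100000 nM (expected range 40000 nM to 250000 nM) and the assay may report only a limit.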

Compound 3, half-maximal inhibitory concentration: > 100000 nM
Compound 3 ended at the assay's limit (the forecaster's own chance of this, stated with the estimate: 60%); the middle value sits exactly at the limit.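

The values of compound 1 and compound 3 in this assay are both limits and not numbers, so no step can be read between them. Going by these compounds, how methoxymethyl compares with hydroxymethyl on the shared core remains open.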